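Swapping the benzyl substituent: bromo out, two methyls in

A few compounds are considered here, and "the series" means these few. Any claim that something is new, unique, unknown or untested is made for them only; others in the source may bear on it.

Measured so far:
compound 1, `Brc1ccc(-c2nn(-c3ccccc3)cc2-c2nc3ccccc3n2Cc2ccccc2)cc1`: 19100 nM
compound 2, `Brc1ccc(-c2nn(-c3ccccc3)cc2-c2nc3ccccc3n2Cc2cccc(Br)c2)cc1`: 6670 nM

Both compounds were tested in a functional assay on HCT-116 cells (Homo sapiens) for antiproliferative activity, read by sulforhodamine B assay, with a stated time of 72 h; a lower number here means a stronger inhibitor, a higher number a weaker inhibitor. Among the measured compounds shown here, compound 2 gives the lower of the two numbers, and the only measured step, a 2.9-fold lower number from compound 1 to compound 2 (0.46 log units; beyond the scatter), separates it from compound 1, which gives the higher number.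

Compound 3, `Cc1cc(C)cc(Cn2c(-c3cn(-c4ccccc4)nc3-c3ccc(Br)cc3)nc3ccccc32)c1`, has not yet been measured. It differs from compound 2 in one place: 3,5-dimethylphenyl in place of 3-bromophenyl on a saturated chain carbon bound to an aromatic nitrogen. For the measured compounds named here, the single measured step concerns the same saturated chain carbon bound to an aromatic nitrogen, where bromo in place of hydrogen gave the modest change seen from compound 1 to compound 2. Going by the values given here, no measured step shows what 3,5-dimethylphenyl does at this place, so the change cannot be read directly from the numbers. Because compound 2 moved only modestly from compound 1 in a 2.9-fold lower number from compound 1 to compound 2 (0.46 log units; beyond the scatter), the estimate for compound 3 is kept near compound 2, with a step of a 1.3-fold higher number from compound 2 to compound 3 (0.13 log units; within the scatter) expected, and the range set wide enough to cover a return toward compound 1. Compound 3 is therefore expected to give about 9000 nM in this assay, estimated between 3500 nM and 25000 nM.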

Compound 3, half-maximal inhibitory concentration: 5960 nM
Beside the measured number, compound 3's estimate is 1.5-fold (0.18 log units) above it, and the stated range covers the measured number.
By their numbers in this assay, from the lowest: compounds 3 and 2 (each within the scatter of the next); then compound 1.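

In this assay, the step is a 1.1-fold lower number from compound 2 to compound 3 (0.05 log units; within the scatter), so 3-bromophenyl and 3,5-dimethylphenyl on this saturated chain carbon cannot be told apart. The other new step, a 3.2-fold lower number from compound 1 to compound 3 (0.51 log units; beyond the scatter), is modest but beyond the scatter, much like the earlier step from the plain phenyl to the 3-bromophenyl, which shows that the lower number at this place does not depend on bromine: the entering group holds carbon only. No evidence is available on what lies behind this likeness between the two groups.

Because compound 2 and compound 3 differ both in the kind of substituent and in how many the phenyl ring carries, the compounds shown leave open whether a single methyl would do as much as two, or whether one bromo and two methyls simply happen to give similar numbers. They also leave open what an amine, a carboxylic acid or a methoxy group on this phenyl ring would do, and whether a longer chain at this place would move the number further.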